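Swapping a Five-Membered Ring and Watching Solubility

The source may hold more compounds than are shown below. What is called first, only, known or untested is meant among the compounds shown, and "the series" means these compounds.

Measured so far:
compound 1 `CC(C)c1noc(-c2cccc(CNc3ccc4[nH]nc(C(=O)O)c4c3)c2O)n1`, 11000 nM
compound 2 `Cc1nc(-c2cccc(CNc3ccc4[nH]nc(C(=O)O)c4c3)c2O)sc1C`, 20000 nM

Compound 1 gives the lowest of the two numbers in a physicochemical assay for solubility, measured as kinetic solubility, at pH 2 (on this read-out higher numbers stand for higher solubility and lower numbers for lower solubility), but its nearest neighbour, compound 2, lies within the scatter: a 1.8-fold higher number from compound 1 to compound 2 (0.26 log units; within the scatter). Compound 3 `Cc1csc(-c2cccc(CNc3ccc4[nH]nc(C(=O)O)c4c3)c2O)n1` differs from compound 1 in one place: 4-methyl-1,3-thiazol-2-yl in place of 3-isopropyl-1,2,4-oxadiazol-5-yl on an aromatic carbon. Going by the values given here, the one related step, from the 3-isopropyl-1,2,4-oxadiazol-5-yl to the 4,5-dimethyl-1,3-thiazol-2-yl, stayed within the scatter, so a move of similar size is expected here, a 1.4-fold higher number from compound 1 to compound 3 (0.13 log units; within the scatter). Compound 3 is therefore estimated at 15000 nM, between 7000 nM and 35000 nM.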

Compound 3, solubility: 5000 nM
The estimate for compound 3 lay 3.0-fold (0.48 log units) above the measured number; the measured number lies below the stated range.
By their numbers in this assay, from the lowest: compound 3; then compounds 1 and 2 (each within the scatter of the next).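

On this assay the two methyl-bearing thiazole rings are not interchangeable at this position: hydrogen in place of methyl gives a 4.0-fold lower number from compound 2 to compound 3 (0.60 log units; beyond the scatter) and this step lies beyond the scatter. Placing 4-methyl-1,3-thiazol-2-yl where 3-isopropyl-1,2,4-oxadiazol-5-yl stood gives a 2.2-fold lower number from compound 1 to compound 3 (0.34 log units; beyond the scatter) and this too lies beyond the scatter, so the result of swapping the ring depends on what the new ring carries. No measurement available here explains either step. Still open, from the compounds shown here alone, is how this ring would read with an amine or a longer chain in place of its methyl.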